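The compounds below may be only part of what the source reports. "The series", "measured", "known", "first", "only" and "open" are said of these compounds alone.

Compound 1 `O=C1NC(=O)N(/N=C/c2ccc(-c3ccc(Cl)cc3)o2)C1O` gives 0.016 umol/kg
Compound 2 `N#Cc1ccc(-c2ccc(/C=N/N3C(=O)NC(=O)C3O)o2)cc1` gives 0.025 umol/kg

In a functional assay on the whole organism (Gastrocnemius, strain Sprague-Dawley) for inhibition, with Rattus norvegicus as the target (a lower number here means that less compound is needed, a higher number that more compound is needed for the effect), compound 2 stands within the scatter of compound 1, so the two values cannot be ranked. Compound 3 `CC(=O)Nc1ccc(-c2ccc(/C=N/N3C(=O)NC(=O)C3O)o2)cc1` differs from compound 2 by one group, as acetamido in place of cyano on an aromatic carbon shows: acetamido in place of cyano on an aromatic carbon. For the measured compounds named here, the one measured step bearing on this is a 1.6-fold higher number from compound 1 to compound 2 (0.19 log units; within the scatter) and it also swaps a group on an aromatic carbon. Going by the values given here, that step is small, but no measured compound carries acetamido. No shift beyond the scatter is expected in this assay in either direction, and the range is kept wide. The expected change is a 1.2-fold higher number from compound 2 to compound 3 (0.08 log units; within the scatter) and this stays within the scatter. For compound 3 the estimate is 0.03 umol/kg with 0.008 umol/kg to 0.1 umol/kg as its range.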

Compound 3, dose for half-maximal effect: > 0.107 umol/kg
Compound 3 ended at the assay's limit (the forecaster's own chance of this, stated with the estimate: 3%); middle value at least 3.5-fold (0.55 log units) from the limit.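

In this assay compound 3 gives > 0.107 umol/kg, which is a limit of the assay and not a number. Chloro and cyano could not be told apart on this aromatic carbon, para to a large group, but acetamido gives a change beyond the scatter: an at least 4.2-fold higher number from compound 2 to compound 3 (0.63 log units; beyond the scatter), and an at least 6.6-fold higher number from compound 1 to compound 3 (0.82 log units; beyond the scatter). On these data alone, this position therefore does not accept every group equally in this assay, though the full size of the change stays unknown.

As far as these compounds go, whether an amine or a carboxylic acid here would behave like acetamido or like chloro and cyano remains open. The compounds shown also cannot tell whether the carbonyl or the amide hydrogen of acetamido goes with the higher number.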